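The compounds below may be only part of what the source reports. "The series", "measured", "known", "first", "only" and "open" are said of these compounds alone.

Compound 3, whose structure is `C=CCOc1cc(C2=C(c3cc(OC)c(OC)c(OC)c3)C(=O)C(O)C2)ccc1OC`, is known in an ADME assay on DU-145 cells (Homo sapiens) for cytotoxicity, read by MTT assay, with a stated time of 72 h (a higher number here means a weaker inhibitor, a lower number a stronger inhibitor), only as a limit: there compound 3 gives > 100 ug/mL. Compound 4, with the structure `COc1ccc(C2=C(c3cc(OC)c(OC)c(OC)c3)C(=O)C(O)C2)cc1NC(=O)c1ccccc1`, differs from it at one place: benzamido in place of allyloxy on an aromatic carbon.

The only measured single step among the compounds shown is the one between compound 1, `COc1ccc(C2=C(c3cc(OC)c(OC)c(OC)c3)C(=O)C(OC(C)=O)C2)cc1Cl`, and compound 2, `COc1ccc(C2=C(c3cc(OC)c(OC)c(OC)c3)C(=O)C(OC(C)=O)C2)cc1O`, which also sit on the shared core. In this assay compound 1 gives 64 ug/mL. Compound 2 is reported as a limit, giving > 100 ug/mL in this assay. That step, an at least 1.5-fold higher number from compound 1 to compound 2 (0.19 log units; that floor lies within the scatter), is a change at the same aromatic carbon that the present change touches, and it led toward weaker inhibition, reaching (the limit of > 100 ug/mL in this assay, at which 2 of the 3 values shown sit). No step shown involves benzamido, so the size of the present change cannot be read from a matching pair.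

Among the measured compounds shown here, with two of three values already at the limit and the one measured step pointing upward, compound 4 is expected to remain a weak inhibitor, with an estimated value of 100 ug/mL, between 45 ug/mL and 220 ug/mL, a step of a number no higher from compound 3 to compound 4 (the limit leaves the size open) that is expected to stay within the scatter.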

Compound 4, half-maximal inhibitory concentration: > 100 ug/mL
Compound 4 gave a limit, no number; the forecaster's own chance of this, stated with the estimate: 55%; the middle value sits exactly at the limit.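

Among the compounds shown here, compound 3 and compound 4 are both reported only as limits in this assay, so no step between them can be read, and compound 4 joins the compounds already there: the limit of > 100 ug/mL in this assay, at which 3 of the 4 values shown sit. The compounds shown leave open whether benzamido in place of allyloxy changes inhibition at all, and by how much.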